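A few compounds are considered here, and "the series" means these few. Any claim that something is new, unique, unknown or untested is made for them only; others in the source may bear on it.

Compound 2, `CCc1ccc2nc(C(=O)Nc3c(F)cc(-c4cccc(F)c4)cc3F)c(C)c(C(=O)O)c2c1`, gives -0.25% in a functional assay on Hep 3B2 cells (Homo sapiens) for antiproliferative activity, read by MTT assay, with a stated time of 24 h, tested at 0.01 ug/mL; on this read-out lower numbers stand for a weaker effect and higher numbers for a stronger effect at the one concentration tested. Among the compounds with values here, it stands lowest of the two numbers so far, and its nearest neighbour is compound 1, `CCc1ccc2nc(C(=O)Nc3c(F)cc(-c4cccc(F)c4)cc3F)c(C)c(O)c2c1`, which gives 0.74% in this assay, so that the only measured step, a number 1 percentage points lower from compound 1 to compound 2 (within the scatter), amounts to no real difference at all. Both compounds sit essentially at zero effect at the one concentration tested.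

Compound 3, `CCOc1ccc2nc(C(=O)Nc3c(F)cc(-c4cccc(F)c4)cc3F)c(C)c(C(=O)O)c2c1`, differs from compound 2 in one place: ethoxy in place of ethyl on an aromatic carbon. Within the data shown here, no measured step concerns this place on the core, so the single step available offers no direct guide; it only shows that the numbers for this series lie near zero and that a change of one group at an aromatic carbon of the core left them there.

On that basis compound 3 is expected to remain near zero in this assay, with the step of a number 0.8 percentage points higher from compound 2 to compound 3 (within the scatter) expected to stay within the scatter. The estimate for compound 3 is 0.5%, with a range from -6% to 8%.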

Compound 3, a percentage reported as inhibition, at one concentration (the size of the read-out at that concentration, not a potency): -0.12%
Estimate against measurement, compound 3: 0.6 percentage points above; measured number inside the range.
By their numbers in this assay, from the lowest: compounds 2, 3 and 1 (each within the scatter of the next).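

Within the data shown here, the step of a number 0.1 percentage points higher from compound 2 to compound 3 (within the scatter) is the first measured change at this position, on the aromatic carbon that is meta to one fused ring and para to the other, and in this assay it shows that ethoxy in place of ethyl, with the oxygen and the hydrogen-bond acceptor it brings, does not move the number beyond the scatter. Among these compounds, the earlier step concerned a different place on the core, so this is the first sign that the number also stays put when this second place is changed, and at the one concentration tested the read-out does not separate ethyl from ethoxy. Nothing measured here gives a reason for this result.

Because compound 2 and compound 3 both lie close to zero, these numbers cannot show whether the position tolerates change or whether the series simply has almost no effect at this concentration. Also open, on these data alone, is whether a different group at this position, such as an amine, a chlorine atom or a longer alkoxy chain, would lift the number clear of the scatter.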